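Hydrogen for Bromo: The Step from Compound 2

This account rests on a few compounds, and the source may have more. Where it says the series, first, only, none or still open, it means among the compounds named here.

Compound 1 `C=C1C[C@]23C[C@@]1(O)CC[C@H]2[C@@]12C=CC(=O)[C@@](C)(C(=O)O1)[C@H]2[C@@H]3C(=O)OC` gives > 10000 nM
Compound 2 `C=C1C[C@]23C[C@@]1(O)CC[C@H]2c1cc(Br)c(O/C=C/C(=O)OC)c(C)c1[C@@H]3C(=O)OC` gives > 10000 nM

In an ADME assay on HEK-293T cells (Homo sapiens) for cytotoxicity, read by luminescence and CellTiter-Glo, with a stated time of 24 h (on this read-out higher numbers stand for weaker inhibition and lower numbers for stronger inhibition), compound 2 stands at > 10000 nM as a limit of the assay, not a number. Compound 3 `C=C1C[C@]23C[C@@]1(O)CC[C@H]2c1ccc(O/C=C/C(=O)OC)c(C)c1[C@@H]3C(=O)OC` differs from compound 2 in one place (hydrogen in place of bromo on an aromatic carbon): hydrogen in place of bromo on an aromatic carbon, ortho to a (2-(methoxycarbonyl)ethenyl)oxy group. In this assay the expected step is a step that the limit leaves unreadable from compound 2 to compound 3 and no larger than the scatter, in either direction. For compound 3 the estimate is 15000 nM with an expected range from 6000 nM to 40000 nM and the assay will most likely report only a limit again.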

Compound 3, half-maximal inhibitory concentration: > 10000 nM
Compound 3 gave a limit, no number; the forecaster's own chance of this, stated with the estimate: 85%; the middle value lies beyond the limit too.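

Compound 2 and compound 3 both end at a limit, not a number, so no step between them can be read: the limit of > 10000 nM in this assay, at which 3 of the 3 values shown sit.

The compounds shown leave open how far hydrogen in place of bromo shifts cytotoxicity, if at all.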